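The compounds below may be only part of what the source reports. "The series", "measured", "known", "first", "only" and "open" are said of these compounds alone.

In a functional assay on BMMC cells (Mus musculus, strain C57BL/6) for inhibition, with stated times of 5 days and 48 h (on this read-out higher numbers stand for weaker inhibition and lower numbers for stronger inhibition), the measured members of the series stand as follows:

compound 1, `C=C1CC[C@@H]2[C@](C)(CNCc3ccccc3)[C@H](O)CC[C@@]2(C)[C@@H]1/C=C/C1=CCOC1=O`: 960 nM
compound 2, `C=C1CC[C@@H]2[C@](C)(CNCc3ccc(C)cc3)[C@H](O)CC[C@@]2(C)[C@@H]1/C=C/C1=CCOC1=O`: 740 nM
compound 3, `C=C1CC[C@@H]2[C@](C)(CNCc3ccc([N+](=O)[O-])cc3)[C@H](O)CC[C@@]2(C)[C@@H]1/C=C/C1=CCOC1=O`: 1340 nM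

Compound 3 holds the highest of the three numbers, yet the steps to it, a 1.4-fold higher number from compound 1 to compound 3 (0.14 log units; within the scatter) and a 1.8-fold higher number from compound 2 to compound 3 (0.26 log units; within the scatter), both sit within the scatter, as does a 1.3-fold lower number from compound 1 to compound 2 (0.11 log units; within the scatter); no ranking among the three is supported.

Compound 4, `C=C1CC[C@@H]2[C@](C)(CNCc3ccco3)[C@H](O)CC[C@@]2(C)[C@@H]1/C=C/C1=CCOC1=O`, differs from compound 3 in one place: furan-2-yl in place of 4-nitrophenyl on a saturated chain carbon bound to an amine nitrogen

Among the measured compounds shown here, no measured step involves the furan-2-yl; the three steps above only vary the group on the aromatic carbon and all stay within the scatter. On that basis no step beyond the scatter is expected, a 1.3-fold lower number from compound 3 to compound 4 (0.13 log units; within the scatter). Compound 4 is estimated at 1000 nM, with a range of 450 nM to 2200 nM.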

Compound 4, half-maximal inhibitory concentration: 1830 nM
For compound 4 the middle estimate is 1.8-fold (0.26 log units) below the measured one; the measured number falls inside the stated range.
By their numbers in this assay, from the lowest: compounds 2, 1, 3 and 4 (each within the scatter of the next, the first and the last beyond it).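

With furan-2-yl on the saturated chain carbon bound to an amine nitrogen, the series shows its first step beyond the scatter in this assay, a 2.5-fold higher number from compound 2 to compound 4 (0.39 log units; beyond the scatter), and this is a modest step. The other two steps, a 1.4-fold higher number from compound 3 to compound 4 (0.14 log units; within the scatter) and a 1.9-fold higher number from compound 1 to compound 4 (0.28 log units; within the scatter), stay within the scatter, so the five-membered ring separates only from the 4-methylphenyl compound. Nothing available accounts for that single separation.

From the compounds shown here alone, whether thiophen-2-yl or pyridin-3-yl would read like furan-2-yl at this place remains open. Going by these compounds, a saturated ring such as cyclohexyl is equally open.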